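This account rests on a few compounds, and the source may have more. Where it says the series, first, only, none or still open, it means among the compounds named here.

Working notes on the series. Compound 1 `Cc1ccc2oc(SCC(=O)Nc3ccc(-c4nc(-c5ccccc5)c(-c5ccccc5)n4C)cc3)nc2c1` gives 24.6% in a functional assay on MCF7 cells (Homo sapiens) for cytotoxicity, read by MTT assay, with a stated time of 24 h, tested at 6.4 ug/mL; on this read-out lower numbers stand for a weaker effect and higher numbers for a stronger effect at the one concentration tested; compound 2 `Cc1nnc(SCC(=O)Nc2ccc(-c3nc(-c4ccccc4)c(-c4ccccc4)n3C)cc2)s1` gives 67.8%; compound 3 `CN(C)/C=C/N1CCN(CC(=O)Nc2ccc(-c3nc(-c4ccccc4)c(-c4ccccc4)n3C)cc2)CC1` gives 11.1%, the lowest of the three. The steps of a number 13.5 percentage points lower from compound 1 to compound 3 (beyond the scatter) and a number 56.7 percentage points lower from compound 2 to compound 3 (beyond the scatter) both exchange a sulfanyl group on the saturated chain carbon bound to a carbonyl carbon for the piperazine-bearing group, and a number 43.2 percentage points higher from compound 1 to compound 2 (beyond the scatter) swaps one sulfanyl group for another. Compound 4 `Cn1c(-c2ccc(NC(=O)CN3CCN(Cc4ccc(Cl)cc4)CC3)cc2)nc(-c2ccccc2)c1-c1ccccc1` differs from compound 3 at the amine nitrogen in a ring: 4-chlorobenzyl in place of 2-(dimethylamino)ethenyl on an amine nitrogen in a ring. For the measured compounds named here, no measured step alters a substituent on that ring nitrogen, so none bears on it directly; the only anchor is that compound 3 sits at the bottom. The expected change is a number 13.9 percentage points higher from compound 3 to compound 4 (beyond the scatter), with the direction uncertain. Compound 4 is estimated at 25%, between 5% and 55%.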

Compound 4, a percentage reported as activity, at one concentration (the size of the read-out at that concentration, not a potency): 33.4%
Beside the measured number, compound 4's estimate is 8.4 percentage points below it, within the range that was stated.
By their numbers in this assay, from the lowest: compound 3; then compounds 1 and 4 (each within the scatter of the next); then compound 2.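

In this assay, for the compounds shown here, 4-chlorobenzyl in place of 2-(dimethylamino)ethenyl on the amine nitrogen in a ring gives a number 22.3 percentage points higher from compound 3 to compound 4 (beyond the scatter) as the first measured change at this position, so the substituent there does affect the read-out. The piperazine-bearing group therefore does not by itself hold a compound at the level of compound 3. No measurement at hand accounts for the step. Still open, as far as these compounds go, is whether the aromatic ring or the chlorine carries the step; plain benzyl or methyl on that nitrogen would separate these.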